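Extending the chain further: compound 2 to compound 3

The source may hold more compounds than are shown below. What is called first, only, known or untested is meant among the compounds shown, and "the series" means these compounds.

In a functional assay on SW480 cells (Homo sapiens) for antiproliferative activity, read by MTT assay, with a stated time of 48 h (a lower number here means a stronger inhibitor, a higher number a weaker inhibitor), compound 1 (`CCCCCC(CCO)n1cnc2c(Cl)ncnc21`) gives > 50000 nM as a limit and not a number. Going by the values given here, compound 2 (`CCCCCCCCC(CCO)n1cnc2c(Cl)ncnc21`) stands at 1370 nM as the only true number so far. Among the compounds with values here, the single measured step is an at least 36-fold lower number from compound 1 to compound 2 (1.56 log units; beyond the scatter) and is large, with a limit at one end. Compound 3 (`CCCCCCCCCCC(CCO)n1cnc2c(Cl)ncnc21`) has ethyl in place of hydrogen on a saturated chain carbon, nine bonds along the chain from an aromatic nitrogen. Within the data shown here, with only that step as a guide, a much smaller move to a lower number is expected, possibly within the scatter. The expected change is a 1.7-fold lower number from compound 2 to compound 3 (0.23 log units; within the scatter) in this assay and a rise is not excluded. Compound 3 is estimated at 800 nM with an expected range of 250 nM to 4000 nM for now.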

Compound 3, half-maximal inhibitory concentration: 3160 nM
Compound 3: middle estimate off by 4.0-fold (0.60 log units), on the low side, within the range that was stated.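

In this assay, adding to the chain no longer lowers the number: a 2.3-fold higher number from compound 2 to compound 3 (0.36 log units; beyond the scatter), so the response to chain length reverses after compound 2, which has the lowest number of the three. Compound 3 still lies well under compound 1, with an at least 15-fold lower number from compound 1 to compound 3 (1.19 log units; beyond the scatter). Compound 1 stands at a limit and not a number, so the true size of that step stays unknown: the limit of > 50000 nM in this assay, at which 1 of the 3 values shown sits.

Going by these compounds, whether a chain of intermediate length between compound 2 and compound 3 would give a lower number remains open. Also open, on these data alone, is whether an amine in place of the hydroxyl would retain activity.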